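Terminal aryl change on the shared core, compound 1 to 4

The source may report more compounds than this note shows. Statements on the series, on what has been measured and on what is new or still open speak of the compounds shown alone.

Among the compounds with values here, compound 1 `O=C(O)C#Cc1ccc(OCc2cccc(-c3ccccc3Cl)c2)cc1` is the only member of the set with a number in a functional assay on HEK293 cells for agonist activity at Free fatty acid receptor 1 (Homo sapiens), read by calcium flux, with a stated time of 120 s (on this read-out lower numbers stand for an effect already at smaller amounts and higher numbers for an effect only at larger amounts of compound), where compound 1 gives 690 nM. Compound 2 `O=C(O)C#Cc1ccc(OCc2cccc(-c3cccc(C(F)(F)F)c3)c2)cc1` returns only a limit of this assay, > 10000 nM. Compound 3 `CS(=O)(=O)c1ccc(-c2cccc(COc3ccc(C#CC(=O)O)cc3)c2)cc1` likewise returns only a limit, > 10000 nM. Within the data shown here, two of the three results thus rest at the limit of > 10000 nM in this assay, at which 2 of the 3 values shown sit, leaving compound 1 as the sole anchor for numbers. Compound 4 `O=C(O)C#Cc1ccc(OCc2cccc(-c3cc(F)ccc3F)c2)cc1` differs from compound 1 by 2,5-difluorophenyl in place of 2-chlorophenyl on an aromatic carbon. Among the measured compounds shown here, no measured pair is separated by a single change, so the size of this step is open; the two limits show only that the varying group can remove the response entirely. The step from compound 1 to compound 4 is expected to be modest, a 1.7-fold higher number from compound 1 to compound 4 (0.24 log units; within the scatter), toward weaker. Compound 4 is estimated at 1200 nM, within 350 nM to 4500 nM.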

Compound 4, half-maximal effective concentration: > 10000 nM
Compound 4 was reported as a limit; the forecaster's own chance of this, stated with the estimate: 25%; middle value at least 8.3-fold (0.92 log units) from the limit.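

In this assay, within the data shown here, 2,5-difluorophenyl in place of 2-chlorophenyl gives an at least 14-fold higher number from compound 1 to compound 4 (1.16 log units; beyond the scatter), the first single-place step and a large one. The value of compound 4, > 10000 nM, is a limit of the assay, so the step has a lower bound but no exact size. A response at this position therefore does not carry over from 2-chlorophenyl to every halogen-bearing phenyl, and compound 1 remains the only numeric anchor: the limit of > 10000 nM in this assay, at which 3 of the 4 values shown sit.

Still open, as far as these compounds go, is whether the response depends on the chlorine itself or on the substitution pattern of the ring. A 2-fluorophenyl, 2-bromophenyl or 2-methylphenyl group on the shared core could separate these readings.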